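A few compounds are considered here, and "the series" means these few. Any claim that something is new, unique, unknown or untested is made for them only; others in the source may bear on it.

Working notes on the series. Two compounds carry results in a functional assay on MDA-MB-231 cells (Homo sapiens) for inhibition, read by MTT assay, with a stated time of 24 h; on this read-out lower numbers stand for stronger inhibition and higher numbers for weaker inhibition. Compound 1, `CCCc1cc2ccccc2nc1-c1cc(-c2ccc(F)cc2)no1`, gives 48400 nM in this assay. Compound 2, `CCc1cc2ccccc2nc1-c1cc(-c2ccc(C(F)(F)F)cc2)no1`, is not placed by a number in this assay: for compound 2 the result is recorded only as the limit > 100000 nM. Compound 2 therefore stands at the weak end of what has been measured, on a limit rather than a value, which is what the limit of > 100000 nM in this assay, at which 1 of the 2 values shown sits, records. Compound 3 is `CCCc1cc2ccccc2nc1-c1cc(-c2ccc(C(F)(F)F)cc2)no1`. Against compound 2 it carries one change, (methyl in place of hydrogen on a saturated chain carbon, two bonds along the chain from an aromatic carbon), that is, methyl in place of hydrogen on a saturated chain carbon, two bonds along the chain from an aromatic carbon. For the measured compounds named here, no step between measured compounds is available for this change, and compound 1 and compound 2 differ in more than one place, so their two values show only that one is a number and the other a limit. The expectation for compound 3 is a small move, none beyond the scatter, with a fair chance of another limit. The estimate for compound 3 is 90000 nM, within 35000 nM to 250000 nM. This would amount to an expected step of an at least 1.1-fold lower number from compound 2 to compound 3 (0.04 log units; that floor lies within the scatter).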

Compound 3, half-maximal inhibitory concentration: 36500 nM
Beside the measured number, compound 3's estimate is 2.5-fold (0.39 log units) above it; measured number inside the range.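

With trifluoromethyl held fixed, the ethyl to propyl change in this assay gives an at least 2.7-fold lower number from compound 2 to compound 3 (0.43 log units; beyond the scatter), so this chain position moves the read-out beyond the scatter and takes the series from a limit to a number. The size of that step is only a floor, because compound 2 is recorded as a limit: the limit of > 100000 nM in this assay, at which 1 of the 3 values shown sits.

With propyl held fixed, trifluoromethyl in place of fluoro on an aromatic carbon gives a 1.3-fold lower number from compound 1 to compound 3 (0.12 log units; within the scatter), which lies within the scatter, so the two propyl compounds read alike in this assay and this aromatic change shows no separable effect here.

As far as these compounds go, a single step fixes no trend with chain length, so it remains open whether a longer chain such as butyl, or a propyl chain ending in an amine or a hydroxyl group, would give a lower or a higher number in this assay. From the compounds shown here alone, it also remains open whether the ethyl to propyl change has the same size with fluoro in place of trifluoromethyl on the aromatic carbon.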